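Aryl swap on the urea of a chloropyrazine urea pair

The source may report more compounds than this note shows. Statements on the series, on what has been measured and on what is new or still open speak of the compounds shown alone.

Compound 1 `O=C(Nc1cccc(CNc2nccnc2Cl)c1)Nc1ccc(F)c(Cl)c1` gives 5020 nM in a functional assay on MGC-803 cells (Homo sapiens) for antiproliferative activity, read by MTT assay, with a stated time of 48 h; on this read-out higher numbers stand for weaker inhibition and lower numbers for stronger inhibition; compound 2 `CCc1ccc(NC(=O)Nc2cccc(CNc3nccnc3Cl)c2)c(CC)c1` gives 6130 nM in this assay, and the two values stand together within the scatter, so neither can be ranked. Compound 3 `O=C(Nc1cccc(CNc2nccnc2Cl)c1)Nc1ccccc1Cl` remains to be measured. It differs from compound 1 by 2-chlorophenyl in place of 3-chloro-4-fluorophenyl on an amide-type nitrogen. Going by the values given here, no step between measured compounds is available to size such a change, and the two measured values show no movement beyond the scatter. The step of a 1.1-fold higher number from compound 1 to compound 3 (0.04 log units; within the scatter) is expected to be small, with no clear direction. Compound 3 is estimated at 5500 nM, within a range of 2500 nM to 12000 nM.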

Compound 3, half-maximal inhibitory concentration: 7130 nM
Compound 3: the middle estimate sits 1.3-fold (0.11 log units) below what was measured; the range from low to high includes it.
By their numbers in this assay, from the lowest: compounds 1, 2 and 3 (each within the scatter of the next).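

In this assay, the first step measured at this position, 2-chlorophenyl in place of 3-chloro-4-fluorophenyl on an amide-type nitrogen, gives a 1.4-fold higher number from compound 1 to compound 3 (0.15 log units; within the scatter) and so does not separate the two compounds. This exchange of aryl groups, which also takes away the fluorine, therefore leaves no rankable difference on this read-out. No measurement bears on why the two values stand so close.

As far as these compounds go, whether an amine or a carboxylic acid on this phenyl ring would move the value beyond the scatter stays open. Equally open, from the compounds shown here alone, is whether any change to the shared core would do so.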